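The source may hold more compounds than are shown below. What is called first, only, known or untested is meant among the compounds shown, and "the series" means these compounds.

Measured in an ADME assay on the whole organism (Mus musculus, strain ICR) for pharmacokinetics, at a dose of 50 mg/kg by the oral route; a lower number here means less compound in the circulation, a higher number more compound in the circulation at the dose given:
- compound 1 `O=C1CC(Oc2ncccn2)CN1c1cnn2c1CN(C(=O)Nc1cc(F)c(F)c(F)c1)C(C1CC1)C2`: 10300 nM
- compound 2 `O=C1CC(c2ncco2)CN1c1cnn2c1CN(C(=O)Nc1cc(F)c(F)c(F)c1)C(C1CC1)C2`: 18000 nM
- compound 3 `C[C@H]1Cn2ncc(N3CC(c4ccccc4)CC3=O)c2CN1C(=O)Nc1cc(F)c(F)c(F)c1`: 6670 nM

Compound 2, at 18000 nM, stands level with compound 1 within the scatter, while compound 3 gives a lower number, 6670 nM. Compound 4 `Cc1nc(C2CC(=O)N(c3cnn4c3CN(C(=O)Nc3cc(F)c(F)c(F)c3)C(C3CC3)C4)C2)no1` has not yet been measured. It carries 5-methyl-1,2,4-oxadiazol-3-yl in place of 1,3-oxazol-2-yl on a saturated ring carbon.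

Among the compounds with values here, one measured step bears on this change, a swap on the same saturated ring carbon: a 1.7-fold higher number from compound 1 to compound 2 (0.24 log units; within the scatter). Within the data shown here, compound 3 differs from the others in more than one place and offers no clean step. One small step cannot fix a direction, so no change beyond the scatter is expected in this assay. The expected step is a 1.3-fold lower number from compound 2 to compound 4 (0.11 log units; within the scatter). For compound 4 the estimated value is 14000 nM, with an expected range from 6500 nM to 28000 nM.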

Compound 4, maximal plasma concentration: 7710 nM
Compound 4: the middle estimate sits 1.8-fold (0.26 log units) above what was measured; low and high end bracket the measured number.
By their numbers in this assay, from the lowest: compounds 3, 4, 1 and 2 (each within the scatter of the next, the first and the last beyond it).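

In this assay the saturated ring carbon two ring bonds from the ring nitrogen now shows a step beyond the scatter, a 2.3-fold lower number from compound 2 to compound 4 (0.37 log units; beyond the scatter) when 5-methyl-1,2,4-oxadiazol-3-yl replaces 1,3-oxazol-2-yl. The same group replacing (pyrimidin-2-yl)oxy gives a 1.3-fold lower number from compound 1 to compound 4 (0.13 log units; within the scatter) and stays within the scatter, so the reading depends on the group that leaves, even though those two leaving groups lie within the scatter of each other. Nothing available on these compounds accounts for the step.

Going by these compounds, it remains open whether the methyl or the five-membered ring of the entering group carries the step, which the 1,2,4-oxadiazol-3-yl group without its methyl would help to settle. Also open, on these data alone, is how a carboxylic acid or an aminomethyl group would read on this same ring carbon.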